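The source may hold more compounds than are shown below. What is called first, only, known or untested is meant among the compounds shown, and "the series" means these compounds.

Working notes on the series. In a functional assay on MCF7 cells (Homo sapiens) for cytotoxicity, read by MTT assay, with a stated time of 48 h (on this read-out higher numbers stand for weaker inhibition and lower numbers for stronger inhibition), compound 1 `CC1(C)CCCC2=CC=C(C=O)CC[C@]21C` gives 167000 nM as its reading. Compound 2 `C=C1CCC[C@]2(C)CCC(c3cn(-c4cccc([N+](=O)[O-])c4)nn3)=CC[C@@]12C` gives 40300 nM there, the lower of the two numbers, and its gap to compound 1 lies beyond the usual scatter. These two compounds differ in more than one place, so the gap is assigned to no single group.

Still unmeasured is compound 3 `C=C1CCC[C@]2(C)CCC(c3cn(-c4ccc(C)cc4)nn3)=CC[C@@]12C` with one change from compound 2: 4-methylphenyl in place of 3-nitrophenyl on an aromatic nitrogen in the form of 4-methylphenyl in place of 3-nitrophenyl on an aromatic nitrogen of a five-membered aromatic ring with 3 nitrogen. For the measured compounds named here, no measured pair varies this group, so the data set no direction for the change. The reading of compound 2 at 40300 nM remains the only anchor, and no step beyond the scatter is expected in this assay for this swap. The estimated shift is a 1.2-fold higher number from compound 2 to compound 3 (0.08 log units; within the scatter) and would stay within the scatter. For compound 3 the expected value is 48000 nM with an estimated range of 19000 nM to 120000 nM around it.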

Compound 3, half-maximal inhibitory concentration: 54900 nM
Estimate against measurement, compound 3: 1.1-fold (0.06 log units) below, within the range that was stated.
By their numbers in this assay, from the lowest: compounds 2 and 3 (each within the scatter of the next); then compound 1.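

In this assay, for the compounds shown here, 4-methylphenyl in place of 3-nitrophenyl on an aromatic nitrogen of the five-membered aromatic ring with 3 nitrogen gives a 1.4-fold higher number from compound 2 to compound 3 (0.13 log units; within the scatter) and this is the first comparison that isolates a single place. The read-out does not separate these two phenyl groups on the shared core, even though the leaving group counts 2 hydrogen-bond acceptors and the entering group counts 0, so this one pair links that difference in acceptor count to no readable shift. No measurement at hand explains this outcome or says what the group does at this position.

Going by these compounds alone, with only one pair at this position, it remains open whether the flat result holds for other kinds of group on the phenyl ring, such as an amine or a carboxylic acid. On these data alone, it is equally open whether a longer alkyl chain or a plain unsubstituted phenyl on the same aromatic nitrogen would stay within the scatter of these two compounds or move the number beyond it.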